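Sulfamate series: removing the hydroxymethyl from compound 3

The source may report more compounds than this note shows. Statements on the series, on what has been measured and on what is new or still open speak of the compounds shown alone.

Compound 3 `NS(=O)(=O)Oc1ccc2c(c1)CN(C(=O)c1cccc(N(CCCO)Cc3ccccc3)c1)CC2` stands highest of the three measured in an assay on HEK293 cells for inhibition of Steryl-sulfatase (Homo sapiens), tested at 1 uM (a lower number here means a weaker effect, a higher number a stronger effect of the compound at the concentration tested), giving 37.3%. Compound 2 `CCN(Cc1cccc(Br)c1)c1cccc(C(=O)N2CCc3ccc(OS(N)(=O)=O)cc3C2)c1` gives 24.9% and compound 1 `CN(C)CCN(CCN(C)C)c1cccc(C(=O)N2CCc3ccc(OS(N)(=O)=O)cc3C2)c1` gives 17.1%; both gaps from compound 3 lie beyond the scatter. Compound 4 `CCN(Cc1ccccc1)c1cccc(C(=O)N2CCc3ccc(OS(N)(=O)=O)cc3C2)c1` differs from compound 3 by hydrogen in place of hydroxymethyl on a saturated chain carbon, two bonds along the chain from a nitrogen on an aromatic ring. Among the compounds with values here, the only measured step, a number 7.8 percentage points higher from compound 1 to compound 2 (within the scatter), alters the substituents on the aromatic nitrogen at a different point and sits within the scatter, so it gives no direct guide to this change. Compound 2, which also carries ethyl on that nitrogen, gives 24.9%. A downward step of a number 9.3 percentage points lower from compound 3 to compound 4 (within the scatter) is therefore expected. Compound 4 is estimated at 28%, within 15% to 42%.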

Compound 4, a percentage reported as inhibition, at one concentration (the size of the read-out at that concentration, not a potency): 69%
Compound 4: middle estimate off by 41 percentage points, on the low side; the whole stated range lies below it.
By their numbers in this assay, from the lowest: compounds 1 and 2 (each within the scatter of the next); then compound 3; then compound 4.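

In this assay, the chain position is far from neutral: 3-hydroxypropyl to ethyl brings a number 31.7 percentage points higher from compound 3 to compound 4 (beyond the scatter), so hydroxymethyl on this saturated chain carbon costs much of the read-out. Hydrogen in place of bromo on an aromatic carbon brings a number 44.1 percentage points higher from compound 2 to compound 4 (beyond the scatter), and benzyl(ethyl)amino in place of bis(2-(dimethylamino)ethyl)amino brings a number 51.9 percentage points higher from compound 1 to compound 4 (beyond the scatter), which places compound 4 above all three others. Nothing at hand bears on the cause of these steps.

Open, from the compounds shown here alone, is whether a methyl or a longer chain such as propyl in place of ethyl keeps this read-out. Also open, going by these compounds, is whether fluoro or methoxy in place of bromo on the aromatic carbon behaves as bromo does.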